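The source may hold more compounds than are shown below. What is called first, only, known or untested is meant among the compounds shown, and "the series" means these compounds.

Of the compounds shown here, two have so far been measured in a functional assay on HCT-116 cells (Homo sapiens) for inhibition, read by sulforhodamine B assay, with a stated time of 48 h, tested at 50 uM (on this read-out lower numbers stand for less inhibition of growth and higher numbers for more inhibition of growth at the one concentration tested), at the single concentration. Compound 1 (`COc1cc(/C=C/C(=O)/C=C/c2ccco2)ccc1OCc1cn(CCCOc2cc(=O)oc3ccccc23)nn1`) gives 51% and stands highest of the two numbers. Compound 2 (`COc1cc(/C=C/C(=O)/C=C/c2ccccc2)ccc1OCc1cn(CCCCOc2cc(=O)oc3ccccc23)nn1`) gives 34% and lies lower by a gap beyond the usual scatter. These two compounds differ in more than one place, so their gap says nothing about any single change.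

Compound 3 (`COc1cc(/C=C/C(=O)/C=C/c2cccs2)ccc1OCc1cn(CCCOc2cc(=O)oc3ccccc23)nn1`) has not yet been measured. It carries thiophen-2-yl in place of furan-2-yl on a double-bonded chain carbon bound to a double-bonded chain carbon, and the rest of compound 1 stays as it is. Each of the two groups is one five-membered aromatic ring with 1 hetero atom. Within the data shown here, no measured pair shows this exchange, so the expectation rests on compound 1 and its 51% as the nearest reference. In this assay the expected step of a number 1 percentage points lower from compound 1 to compound 3 (within the scatter) is small, with no clear direction and nothing beyond the scatter. For compound 3 the estimated value is 50% with an expected range from 35% to 65% in this read-out.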

Compound 3, percent growth inhibition at one concentration: 58%
Compound 3: middle estimate off by 8 percentage points, on the low side; the measured number falls inside the stated range.
By their numbers in this assay, from the lowest: compound 2; then compounds 1 and 3 (each within the scatter of the next).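

In this assay the exchange of furan-2-yl for thiophen-2-yl on a double-bonded chain carbon bound to a double-bonded chain carbon reads as a number 7 percentage points higher from compound 1 to compound 3 (within the scatter) and gives the series its first comparison of a single change. With the rest of compound 1 kept as it is, oxygen and sulfur in this one five-membered aromatic ring cannot be told apart by this read-out at the single concentration tested, so this position accepts the exchange without a separation beyond the usual scatter. No measurement shown here accounts for the step, and the pair offers no explanation of its own.

The compounds shown place only these two rings in a single-change comparison at this position, so it remains open whether a group of another kind, such as a pyridin-3-yl ring or a carboxylic acid, would shift the number beyond the scatter. As far as these compounds go, it also remains open whether the same exchange would leave the number within the scatter on a different chain joining the triazole to the rest of the molecule.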